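This account rests on a few compounds, and the source may have more. Where it says the series, first, only, none or still open, it means among the compounds named here.

Compound 1 `C=C1C(=O)[C@]23C[C@@]1(O)CC[C@H]2c1ccc(O)c(C)c1[C@@H]3Cn1cc(-c2ccccn2)nn1` is the starting point of this small set. In a functional assay on MCF7 cells (Homo sapiens) for cytotoxicity, read by MTT assay, with a stated time of 4 days (a higher number here means a weaker inhibitor, a lower number a stronger inhibitor), compound 1 gives 2240 nM. Compound 2 `C=C1C(=O)[C@]23C[C@@]1(O)CC[C@H]2c1ccc(O)c(C)c1[C@@H]3Cn1cc(-c2ccc(C(F)(F)F)cc2)nn1` keeps the core of compound 1 and differs from it only by 4-(trifluoromethyl)phenyl in place of pyridin-2-yl on an aromatic carbon. In this assay compound 2 gives 1840 nM, so the change amounts to a 1.2-fold lower number from compound 1 to compound 2 (0.09 log units; within the scatter), and the two compounds cannot be told apart by this read-out.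

Compound 3 `C=C1C[C@]23C[C@@]1(O)CC[C@H]2c1cc(Br)c(O)c(C)c1[C@@H]3Cn1cc(-c2ccccn2)nn1` carries a different core, and the difference between the core of compound 3 and the core of compound 1 is not broken down here. In this assay compound 3 gives only a limit of the assay, > 20000 nM. Going by the values given here, this is the limit of > 20000 nM in this assay, at which 1 of the 3 values shown sits, so no number is known for compound 3 and no step from compound 1 to compound 3 can be sized.

Compound 4 `C=C1C[C@]23C[C@@]1(O)CC[C@H]2c1cc(Br)c(O)c(C)c1[C@@H]3Cn1cc(-c2ccc(C(F)(F)F)cc2)nn1` has not yet been measured. It stands to compound 3 as compound 2 stands to compound 1: it differs by 4-(trifluoromethyl)phenyl in place of pyridin-2-yl on an aromatic carbon, the same change made at the same place. Since the same change from compound 1 to compound 2 gave a 1.2-fold lower number from compound 1 to compound 2 (0.09 log units; within the scatter), and since compound 3 itself sits at > 20000 nM, the step from compound 3 to compound 4 is expected to be small, about a number no higher from compound 3 to compound 4 (the limit leaves the size open), and compound 4 is expected to give about 20000 nM in this assay, within roughly 8000 nM to 50000 nM, most likely again reported only as a limit.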

Compound 4, half-maximal inhibitory concentration: 8100 nM
The estimate for compound 4 lay 2.5-fold (0.39 log units) above the measured number, within the range that was stated.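

On the core of compound 3, 4-(trifluoromethyl)phenyl in place of pyridin-2-yl gives an at least 2.4-fold lower number from compound 3 to compound 4 (0.39 log units; beyond the scatter) in this assay, so on this core the change is large enough to be read beyond the usual scatter, whereas on the core of compound 1 it is not. The two steps can be compared only as far as the following goes: the same change on two cores in this assay, a 1.2-fold lower number (0.09 log units; within the scatter) from compound 1 to compound 2 and an at least 2.4-fold lower number (0.39 log units; beyond the scatter) from compound 3 to compound 4; the limit leaves it open whether they differ. This shows that the change can be carried onto the second core and that compound 4 there gives a measured number rather than a limit, but it does not show that the size of the step depends on the core, since the starting point on that core is not a number: the limit of > 20000 nM in this assay, at which 1 of the 4 values shown sits.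

The compounds shown leave open how other groups on the same carbon of the five-membered aromatic ring with 3 nitrogen, such as an unsubstituted phenyl, a carboxylic acid or a longer chain ending in an amine, would read in this assay. They also leave open which part of the difference between the two cores separates them, and whether the same change would behave alike on a third core.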